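A few compounds are considered here, and "the series" means these few. Any claim that something is new, unique, unknown or untested is made for them only; others in the source may bear on it.

Measured so far in a functional assay on the whole organism (strain Wistar) for inhibition, with Rattus norvegicus as the target, read by paw edema, with a stated time of 1 h, at a dose of 10 mg/kg by the intraperitoneal route; on this read-out lower numbers stand for less inhibition and higher numbers for more inhibition at the one dose given (going by the name of the read-out):
Compound 1 `O=C(N/N=C/c1ccc(F)cc1)c1cccnc1Nc1cccc(C(F)(F)F)c1` gives 43.2%.
Compound 2 `O=C(N/N=C/c1cccc(O)c1)c1cccnc1Nc1cccc(C(F)(F)F)c1` gives 63.8%.
Compound 3 `O=C(N/N=C/c1ccc(O)cc1)c1cccnc1Nc1cccc(C(F)(F)F)c1` gives 70.5%.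

Compound 3 has the highest number of the three. Its gap to compound 2 lies within the usual scatter, so the two cannot be ranked against each other, while compound 1 sits clearly lower: a number 27.3 percentage points higher from compound 1 to compound 3 (beyond the scatter). Compound 4 `COc1ccc(/C=N/NC(=O)c2cccnc2Nc2cccc(C(F)(F)F)c2)c(OC)c1` has not yet been measured. It differs from compound 3 in one place: 2,4-dimethoxyphenyl in place of 4-hydroxyphenyl on a carbon with a double bond to nitrogen.

Within the data shown here, no measured step exchanges a hydroxy group for methoxy groups, so the evidence is indirect. Both steps from compound 1 to a hydroxy-bearing compound raised the number, a number 20.6 percentage points higher from compound 1 to compound 2 (beyond the scatter) and a number 27.3 percentage points higher from compound 1 to compound 3 (beyond the scatter), whereas the step between the two hydroxy compounds, a number 6.7 percentage points higher from compound 2 to compound 3 (within the scatter), lay within the scatter. Compound 4 carries no hydroxy group, so a fall from compound 3 is expected, of a size like a number 20.5 percentage points lower from compound 3 to compound 4 (beyond the scatter). Compound 4 is therefore estimated at 50%, likely between 32% and 68% in this assay.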

Compound 4, a percentage reported as inhibition, in the whole organism at one dose (the size of the read-out at that dose, not a potency): 55.7%
For compound 4 the middle estimate is 5.7 percentage points below the measured one; measured number inside the range.
By their numbers in this assay, from the lowest: compound 1; then compounds 4, 2 and 3 (each within the scatter of the next, the first and the last beyond it).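

At this position, on a carbon with a double bond to nitrogen, a ring without a hydroxy group can also exceed the 4-fluorophenyl compound in this assay: 2,4-dimethoxyphenyl gives a number 12.5 percentage points higher from compound 1 to compound 4 (beyond the scatter), so a gain over compound 1 is not confined to the hydroxy compounds. The same group falls short of 4-hydroxyphenyl, with a number 14.8 percentage points lower from compound 3 to compound 4 (beyond the scatter), yet the change from 3-hydroxyphenyl, a number 8.1 percentage points lower from compound 2 to compound 4 (within the scatter), cannot be told apart from scatter, so the data do not show that a hydroxy group is needed for a value in this range. Nothing measured here accounts for these differences.

The effect of each methoxy group alone remains open, since 2,4-dimethoxyphenyl carries both together and 4-methoxyphenyl does not appear among these compounds. How an aminophenyl or carboxyphenyl ring would compare at this position is also unknown.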